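The source may hold more compounds than are shown below. What is called first, only, known or untested is meant among the compounds shown, and "the series" means these compounds.

Measured compounds in an ADME assay on Huh-7 cells (Homo sapiens) for cytotoxicity; on this read-out lower numbers stand for higher toxicity in this test and higher numbers for lower toxicity in this test:
- compound 1, `NC(=S)Nc1cccc(OCCCCCN2CCN(c3ccc(Cl)cc3)C2=O)c1`: 39000 nM
- compound 2, `NC(=S)Nc1cccc(OCCCCCN2CCN(c3cccc4ccccc34)C2=O)c1`: 15000 nM
- compound 3, `NC(=S)Nc1cccc(OCCCCCN2CCN(c3ccc(Cl)c(Cl)c3)C2=O)c1`: 13000 nM

Compound 1 stands highest of the three numbers in this assay; its nearest neighbour is compound 2, a 2.6-fold lower number from compound 1 to compound 2 (0.41 log units; beyond the scatter), and its furthest is compound 3, a 3.0-fold lower number from compound 1 to compound 3 (0.48 log units; beyond the scatter). Compound 2 and compound 3 sit within the scatter of each other, a 1.2-fold lower number from compound 2 to compound 3 (0.06 log units; within the scatter).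

Compound 4, `NC(=S)Nc1cccc(OCCCCCN2CCN(c3ccc(C4CCCCC4)cc3)C2=O)c1`, has not been measured in this assay. It differs from compound 1 in one place: cyclohexyl in place of chloro on an aromatic carbon. Going by the values given here, no measured pair shows this exact exchange. The two steps that start from compound 1 both alter the ring on the amide-type nitrogen in a ring and both lower the number by a modest amount, a 2.6-fold lower number from compound 1 to compound 2 (0.41 log units; beyond the scatter) and a 3.0-fold lower number from compound 1 to compound 3 (0.48 log units; beyond the scatter). A lowering of similar size is therefore expected for compound 4, a 2.6-fold lower number from compound 1 to compound 4 (0.41 log units; beyond the scatter). The estimate for compound 4 in this assay is 15000 nM, with a range from 6000 nM to 40000 nM.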

Compound 4, half-maximal cytotoxic concentration: 12000 nM
Compound 4: middle estimate off by 1.3-fold (0.10 log units), on the high side; measured number inside the range.
By their numbers in this assay, from the lowest: compounds 4, 3 and 2 (each within the scatter of the next); then compound 1.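

In this assay, cyclohexyl in place of chloro on the aromatic carbon para to a large group gives a 3.3-fold lower number from compound 1 to compound 4 (0.51 log units; beyond the scatter), so the exchange of a single chlorine for a six-membered non-aromatic carbon ring brings only a modest change in the number. With this result, all three single changes starting from compound 1 lower the number, and none of the compounds shown goes against this; the earlier steps changed the whole ring or added a chloro, whereas this one exchanges the chloro at this position directly. No measurement shown here explains the step.

As far as these compounds go, it remains open whether a group carrying a heteroatom at this position, such as an amine, a hydroxyl or a carboxylic acid, would lower the number in the same way. A smaller group such as methyl, or a longer alkyl chain, would show whether the size of the group matters here.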